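A few compounds are considered here, and "the series" means these few. Any claim that something is new, unique, unknown or untested is made for them only; others in the source may bear on it.

Working notes on the series. The shared core, seen in compound 2 `N#Cc1cnc(NCc2cnccc2C(F)(F)F)cc1NC[C@H]1CC[C@@H](O)CC1`, carries a (4-hydroxycyclohexyl)methyl group on a nitrogen on an aromatic ring. In an assay on isolated protein for inhibition of protein kinase C theta type (Homo sapiens), read by TR-FRET, with a stated time of 2 h (a lower number here means a stronger inhibitor, a higher number a weaker inhibitor), compound 2 gives 58 nM, the second highest of the three numbers in hand. Compound 3 `CC1(C)C[C@H](Nc2cc(NCc3cnccc3C(F)(F)F)ncc2C#N)CC(C)(C)[C@H]1O` gives 20 nM in this assay, a gap from compound 2 that lies beyond the scatter. Compound 1 `N#Cc1cnc(NCc2ccccc2C(F)(F)F)cc1N[C@H]1CC[C@H](O)CC1` gives 4000 nM in this assay, the highest of the three and far above compound 2; compound 1 differs from compound 2 in more than one place, so no single step can be read from that pair.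

Compound 4 `CC1(C)[C@@H](Nc2cc(NCc3cnccc3C(F)(F)F)ncc2C#N)C[C@@H]1C(N)=O` has not yet been measured. It differs from compound 2 in one place: 3-carbamoyl-2,2-dimethylcyclobutyl in place of (4-hydroxycyclohexyl)methyl on a nitrogen on an aromatic ring. Among the measured compounds shown here, no pair of measured compounds differs in only one place, so the size of this step has no direct precedent in the data. The expectation rests on compound 2 at 58 nM and compound 3 at 20 nM, both low numbers on the same core. The step of a 1.5-fold lower number from compound 2 to compound 4 (0.16 log units; within the scatter) is expected to be small, toward a slightly lower number but not beyond the scatter. Compound 4 is estimated at 40 nM, with a range of 10 nM to 160 nM.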

Compound 4, half-maximal inhibitory concentration: 1100 nM
The estimate for compound 4 lay 28-fold (1.44 log units) below the measured number, outside the stated range (above it).
By their numbers in this assay, from the lowest: compound 3; then compound 2; then compound 4; then compound 1.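

In this assay, the group on a nitrogen on an aromatic ring now has its first single-place reading: 3-carbamoyl-2,2-dimethylcyclobutyl in place of (4-hydroxycyclohexyl)methyl gives a 19-fold higher number from compound 2 to compound 4 (1.28 log units; beyond the scatter), so the number at this position can move by a large step with a one-place change. The counts of hydrogen-bond donors and acceptors are the same on both sides of this step and neither group carries a net charge, so those counts do not separate the two groups, although the heavy-atom count, the ring size and the oxygen-bearing function all change. Nothing in hand speaks to the reason for the step.

Among the compounds shown here, the single step changes the ring, the methyl link to the nitrogen, the two methyl groups and the carbamoyl function together, so the share of each in the step remains open. Also open, going by these compounds, is how a carboxylic acid or an amine in place of the carbamoyl on the same 2,2-dimethylcyclobutyl ring would read, and whether a hydroxyl on that ring would read differently from the carbamoyl.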